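The compounds below may be only part of what the source reports. "The series", "measured", "known", "first", "only" and "open" are said of these compounds alone.

Measured so far: compound 1, `CN(C)c1ccc(/C=C2\S/C(=N\c3csc(-c4ccc(Cl)cc4)c3)NC2=O)cc1`, with 400 nM; compound 2, `O=C1N/C(=N/c2csc(-c3ccc(Cl)cc3)c2)S/C1=C\c1ccc(Br)cc1`, with 2500 nM, both in a functional assay on MCF7 cells (Homo sapiens) for cytotoxicity, read by MTT assay, with a stated time of 72 h; on this read-out higher numbers stand for weaker inhibition and lower numbers for stronger inhibition.

Among the measured compounds shown here, compound 2 has the higher of the two numbers in this assay, and its nearest neighbour is compound 1, reached by the only measured step, a 6.3-fold higher number from compound 1 to compound 2 (0.80 log units; beyond the scatter). Compound 3, `O=C1N/C(=N/c2csc(-c3ccc(Cl)cc3)c2)S/C1=C\c1ccc(O)cc1`, is not yet measured; it differs from compound 2 by hydroxy in place of bromo on an aromatic carbon. For the measured compounds named here, no measured step shows this same change, so the expectation rests loosely on that one step. The estimated step is a 1.7-fold lower number from compound 2 to compound 3 (0.22 log units; within the scatter). In this assay compound 3 is expected to give 1500 nM, with a range from 400 nM to 6000 nM.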

Compound 3, half-maximal inhibitory concentration: > 50000 nM
Compound 3 gave a limit, no number; the forecaster's own chance of this, stated with the estimate: 5%; middle value at least 33-fold (1.52 log units) away from the limit.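

In this assay compound 3 gives > 50000 nM, which is a limit of the assay and not a number. Hydroxy para to a large group gives an at least 20-fold higher number from compound 2 to compound 3 (1.30 log units; beyond the scatter), and in place of dimethylamino it gives an at least 120-fold higher number from compound 1 to compound 3 (2.09 log units; beyond the scatter). The earlier compounds shown here showed only a modest change at this position, whereas this single exchange, with the core unchanged, moves the read-out out of measurable range.

As far as these compounds go, the true size of both steps remains unknown. Also open, from the compounds shown here alone, is whether methoxy or a primary amine at this position would give a measurable number.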